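The source may report more compounds than this note shows. Statements on the series, on what has been measured and on what is new or still open speak of the compounds shown alone.

Series notes, cytotoxicity on the shared core.

Three compounds have been run in an ADME assay on MT2 cells (Homo sapiens) for cytotoxicity, read by MTT assay; a higher number here means that more compound is tolerated, a lower number that less compound is tolerated. Compound 1 `Fc1cccc(F)c1Cc1cnc(Nc2ccc(-c3ccncc3)c(Cl)c2)o1` gives 9300 nM. Compound 3 `Fc1cccc(F)c1Cc1cnc(Nc2ccc(CCOc3ccncc3)cc2)o1` gives 11000 nM. Compound 2 `COCc1ccc(Nc2nnc(Cc3c(Cl)cccc3Cl)o2)cc1` gives 100000 nM, the highest of the three numbers: the gap to compound 3 is the nearer one and the gap to compound 1 the wider one, and both lie beyond the scatter, so compound 2 is the best tolerated of the three measured compounds.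

The next compound, compound 4 `Clc1cccc(Cl)c1Cc1nnc(Nc2ccc(COCc3ccccn3)cc2)o1`, is related to compound 2 by one change: pyridin-2-yl in place of hydrogen on a saturated chain carbon bound to an oxygen on a saturated carbon. Within the data shown here, no pair of measured compounds differs only in this way, so there is nothing in the measured set that tells what this addition does to tolerated concentration. Compound 1 and compound 3 carry different cores and different side chains and give lower numbers than compound 2, but neither isolates the pyridin-2-yl addition.

Among the measured compounds shown here, with no direct precedent, the expectation for compound 4 is a modest move downward in this assay, expressed as the estimated step of a 1.7-fold lower number from compound 2 to compound 4 (0.22 log units; within the scatter). Compound 4 is thus expected to give 60000 nM, with a range from 20000 nM to 100000 nM.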

Compound 4, half-maximal cytotoxic concentration: > 100000 nM
Compound 4: only a limit was reported (the forecaster's own chance of this, stated with the estimate: 35%); at least 1.6-fold (0.22 log units) between middle value and limit.
By their numbers in this assay, from the lowest: compounds 1 and 3 (each within the scatter of the next); then compound 2.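

In this assay compound 4 gives > 100000 nM, which is a limit of the assay and not a number. Pyridin-2-yl on a saturated chain carbon bound to an oxygen on a saturated carbon gives the first reading for a change at this position, and the step is a number no lower from compound 2 to compound 4 (the limit leaves the size open), so this position takes the addition with no drop in tolerated concentration seen in this pair. Whether the addition raises the number at all cannot be read, and the reading is capped by the top of the assay's range: the limit of > 100000 nM in this assay, at which 1 of the 4 values shown sits.

The pair leaves open whether this tolerance belongs to pyridin-2-yl or extends to other groups on the same chain carbon, such as a plain phenyl ring, a primary amine, a carboxylic acid or a longer alkyl chain. From the compounds shown here alone, the effect of the same addition on the core of compound 3, where the number is lower than for compound 2, also stays open, and a reading there could fall within the range of the assay.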